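Halogen pattern on the benzyl group: compound 2 to compound 3

The source may report more compounds than this note shows. Statements on the series, on what has been measured and on what is new or still open speak of the compounds shown alone.

Measured so far in an assay on FRT cells for positive allosteric modulation of Cystic fibrosis transmembrane conductance regulator variant N1303K (Homo sapiens), in the presence of a further agent that is not named here; a higher number here means that more compound is needed for the effect, a lower number that less compound is needed:
compound 1 `COc1ccc2[nH]c3c(c2c1)CCNC31CCN(Cc2ccc([N+](=O)[O-])cc2F)CC1` — 5900 nM
compound 2 `COc1ccc2[nH]c3c(c2c1)CCNC31CCN(Cc2cc(F)cc(Cl)c2)CC1` — 2500 nM

In this assay compound 2 gives 2500 nM and holds the lowest number of the two measured compounds; the nearest is compound 1, which gives 5900 nM. Among the compounds with values here, the only measured step is a 2.4-fold lower number from compound 1 to compound 2 (0.37 log units; beyond the scatter), a modest change in which the whole aryl portion of the benzyl group was exchanged.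

Compound 3 `COc1ccc2[nH]c3c(c2c1)CCNC31CCN(Cc2c(F)ccc(Cl)c2F)CC1` differs from compound 2 in one place: 3-chloro-2,6-difluorophenyl in place of 3-chloro-5-fluorophenyl on a saturated chain carbon bound to an amine nitrogen in a ring. The shared core and the benzylic attachment are unchanged; only the halogen count and pattern on the aryl ring move.

Within the data shown here, no measured step alters the halogen pattern while keeping the aryl ring otherwise the same, so the step from compound 1 to compound 2 bears on this change only loosely. It shows that aryl exchange on this position moves the number modestly at most. A step of about that size or smaller is therefore expected here, without a clear direction. Compound 3 is estimated at 2500 nM, in the range 900 nM to 7000 nM. The expected step from compound 2 is no change at the digits printed from compound 2 to compound 3 (within the scatter), which is within the usual scatter.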

Compound 3, half-maximal effective concentration: 1500 nM
For compound 3 the middle estimate is 1.7-fold (0.22 log units) above the measured one, within the range that was stated.
By their numbers in this assay, from the lowest: compounds 3 and 2 (each within the scatter of the next); then compound 1.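

In this assay, the aryl group on a saturated chain carbon bound to an amine nitrogen in a ring tolerates a change of halogen count and pattern: the exchange of 3-chloro-5-fluorophenyl for 3-chloro-2,6-difluorophenyl gives a 1.7-fold lower number from compound 2 to compound 3 (0.22 log units; within the scatter) and leaves compound 2 and compound 3 unordered. Compound 3 also adds a second comparison with the nitro-bearing group, a 3.9-fold lower number from compound 1 to compound 3 (0.59 log units; beyond the scatter), so both aryl groups carrying only halogens now give lower numbers than the 2-fluoro-4-nitrophenyl group of compound 1, a pattern that rests on these three compounds alone. Nothing available explains either step or separates the contribution of the added fluorine from that of the shifted halogen pattern.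

The compounds shown leave open what the chlorine and each fluorine contribute separately, and whether a plain benzyl group, a methoxy-substituted benzyl group or a nitrile-substituted benzyl group would stay in the same range. They also leave open whether a longer chain between the ring amine nitrogen and the aryl group, or a pyridine ring in place of the benzene ring, would carry the numbers further down.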